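Benzyl in place of cyclohexylmethyl on the shared core

A few compounds are considered here, and "the series" means these few. Any claim that something is new, unique, unknown or untested is made for them only; others in the source may bear on it.

Measured compounds:
compound 1 `c1ccc(Oc2ccc3c(NCCCNCc4ccco4)ccnc3c2)cc1` gives 9.28 in a physicochemical assay for acid dissociation;
compound 2 `COc1ccc(F)cc1CNCCCNc1ccnc2cc(Cc3ccccc3)ccc12` gives 9.47;
compound 3 `c1coc(CNCCCNc2ccnc3cc(CC4CCCCC4)ccc23)c1` gives 9.47.

Compound 3 stands level with compound 2 at the digits shown, the two together the highest of the three numbers, and its nearest neighbour is compound 2, with compound 1 furthest away. Among the compounds with values here, the one step measured at this position, a number 0.19 log units higher from compound 1 to compound 3 (within the scatter), stayed within the scatter.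

Compound 4 `c1ccc(Cc2ccc3c(NCCCNCc4ccco4)ccnc3c2)cc1` differs from compound 3 in one place: phenyl in place of cyclohexyl on a saturated chain carbon bound to an aromatic carbon. Compound 2 carries a benzyl group on the same core and matches compound 3 at the digits shown. Within the data shown here, since the only step at this position lay within the scatter, compound 4 is expected to show a number 0.02 log units lower from compound 3 to compound 4 (within the scatter), no more than the scatter. Compound 4 is therefore estimated at 9.45, within 9.2 to 9.7.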

Compound 4, acid dissociation constant: 9.47
The estimate for compound 4 lay 0.02 log units below the measured number, within the range that was stated.
By their numbers in this assay, from the lowest: compounds 1, 2, 3 and 4 (each within the scatter of the next).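

In this assay, phenyl in place of cyclohexyl gave no change at the digits printed from compound 3 to compound 4 (within the scatter), and furan-2-yl in place of 5-fluoro-2-methoxyphenyl on a saturated chain carbon bound to an amine nitrogen gave no change at the digits printed from compound 2 to compound 4 (within the scatter), so a second place on the molecule now also shows a step within the scatter. Benzyl in place of phenoxy gave a number 0.19 log units higher from compound 1 to compound 4 (within the scatter), the same size as cyclohexylmethyl in place of phenoxy, which gave a number 0.19 log units higher from compound 1 to compound 3 (within the scatter). No measurement at hand explains these steps. The compounds shown leave open whether an amine or a carboxylic acid on this aromatic carbon would give a step beyond the scatter.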